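The compounds below may be only part of what the source reports. "The series", "measured", "known", "first", "only" and "open" are said of these compounds alone.

Measured so far in a physicochemical assay for solubility, read by HPLC, in phosphate buffer, at pH 6.5; a lower number here means a less soluble compound, a higher number a more soluble compound:
- compound 1 `COC(=O)C1=C(CN2CC3CC2CO3)NC(c2nccs2)=NC1(C)c1ccc(F)cc1`: 564 ug/mL
- compound 2 `COC(=O)C1=C(CN2CCC(C(F)(F)F)C2)NC(c2nccs2)=NC1(C)c1ccc(F)cc1`: 13 ug/mL

Compound 2, at 13 ug/mL, is the lower of the two numbers, and the gap to compound 1 lies beyond the scatter. The next structure is compound 3 `COC(=O)C1=C(COC2CCOC2)NC(c2nccs2)=NC1(C)c1ccc(F)cc1`, with this change: (oxolan-3-yl)oxy in place of 3-(trifluoromethyl)pyrrolidin-1-yl on a saturated chain carbon bound to a double-bonded ring carbon.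

Among the compounds with values here, one measured step bears on this place: a 43-fold lower number from compound 1 to compound 2 (1.64 log units; beyond the scatter), a large step. Read in reverse, it suggests upward movement, since compound 1, at 564 ug/mL, also lacks the 3-(trifluoromethyl)pyrrolidin-1-yl group. Within the data shown here, no measured compound carries (oxolan-3-yl)oxy, and a single step gives only a rough guide to size. A rise in this assay beyond the scatter is expected, though smaller than the full measured gap. The expected step is a 12-fold higher number from compound 2 to compound 3 (1.06 log units; beyond the scatter). For compound 3 the estimated value is 150 ug/mL, with an expected range of 40 ug/mL to 500 ug/mL.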

Compound 3, solubility: 30 ug/mL
The estimate for compound 3 lay 5.0-fold (0.70 log units) above the measured number, and the stated range ends above it.
By their numbers in this assay, from the lowest: compound 2; then compound 3; then compound 1.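

In this assay, (oxolan-3-yl)oxy in place of 3-(trifluoromethyl)pyrrolidin-1-yl gives only a 2.3-fold higher number from compound 2 to compound 3 (0.36 log units; beyond the scatter) and stays well short of compound 1, with a 19-fold lower number from compound 1 to compound 3 (1.27 log units; beyond the scatter) as the larger step. Losing the trifluoromethyl group is therefore not enough at this position to recover the number of compound 1. Among these compounds, an oxygen-bearing group does not by itself secure a high number either, as compound 3 shows. Nothing available explains the differences among these three groups.

As far as these compounds go, whether the number of compound 1 depends on the nitrogen attached to the chain carbon or on the whole group remains open. A morpholin-4-yl or dimethylamino group on the same saturated chain carbon would help separate those two readings.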